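The source may hold more compounds than are shown below. What is called first, only, known or untested is meant among the compounds shown, and "the series" means these compounds.

The series shares the core of compound 1, `CC1=CC[C@H](C(C)(C)NC(=S)N/N=C/c2cccs2)CC1`. In an ADME assay on Vero cells (Chlorocebus sabaeus) for inhibition, read by sulforhodamine B assay, with a stated time of 48 h (a lower number here means a stronger inhibitor of growth, a higher number a weaker inhibitor of growth), compound 1 gives 13400 nM. Compound 2, `CC1=CC[C@H](C(C)(C)NC(=S)N/N=C(\C)c2ccccc2)CC1`, reaches only a limit: in this assay compound 2 gives > 100000 nM, which is a limit of the assay and not a number. Compound 3, `COc1ccc(/C(C)=N/NC(=S)NC(C)(C)[C@H]2CC=C(C)CC2)cc1`, likewise stops at a limit: in this assay compound 3 gives > 100000 nM, again a limit rather than a number. Between these two neighbours the change is a step that the two limits leave unreadable from compound 2 to compound 3. Compound 3 thus stands at the limit, and the limit of > 100000 nM in this assay, at which 2 of the 3 values shown sit, shows that compound 2 sits there as well, while compound 1 alone returns a number. Compound 4, `CC1=CC[C@H](C(C)(C)NC(=S)N/N=C(\C)c2ccc([N+](=O)[O-])cc2)CC1`, differs from compound 3 by nitro in place of methoxy on an aromatic carbon. For the measured compounds named here, only the step from compound 2 to compound 3 touches the same ring, and its size cannot be read; no measured step involves a nitro group. No move beyond the scatter is expected, and compound 4 is expected to remain at the limit. The estimate for compound 4 in this assay is 100000 nM, with a range from 30000 nM to 300000 nM, which amounts to an expected step of a number no higher from compound 3 to compound 4 (the limit leaves the size open).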

Compound 4, concentration for total growth inhibition: > 100000 nM
Compound 4 ended at the assay's limit; the forecaster's own chance of this, stated with the estimate: 70%; the middle value lies on the limit itself.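

For the compounds shown here, compound 2, compound 3 and compound 4 all stop at a limit and not at a number, so no new step among them can be read: the limit of > 100000 nM in this assay, at which 3 of the 4 values shown sit. The compounds shown leave open whether nitro, methoxy and hydrogen on the aromatic carbon differ at all in this assay.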